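Phenyl in Place of Dimethoxyphenyl: an Expected Inhibition

The source may report more compounds than this note shows. Statements on the series, on what has been measured and on what is new or still open speak of the compounds shown alone.

In a functional assay on the whole organism (strain albino) for inhibition, with Rattus norvegicus as the target, read by paw edema, with a stated time of 3 h, at a dose of 0.28 mmol/kg by the oral route (on this read-out higher numbers stand for more inhibition at the one dose given (going by the name of the read-out) and lower numbers for less inhibition), three compounds have been measured:
compound 1 `COc1ccc(-c2nnc(SCC(=O)c3ccccc3)n2-c2ccccc2)cc1OC` gives 59%
compound 2 `C=CCn1c(SCC(=O)c2ccccc2)nnc1-c1ccc(OC)c(OC)c1` gives 64%
compound 3 `COc1ccc(-c2nnc(SC/C(=N/O)c3ccccc3)n2-c2ccccc2)cc1OC` gives 67%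

Compound 1 stands lowest of the three numbers, but both steps away from it lie within the scatter: a number 5 percentage points higher from compound 1 to compound 2 (within the scatter) and a number 8 percentage points higher from compound 1 to compound 3 (within the scatter). Compound 4 `O=C(CSc1nnc(-c2ccccc2)n1-c1ccccc1)c1ccccc1` has not yet been measured; it differs from compound 1 by phenyl in place of 3,4-dimethoxyphenyl on an aromatic carbon. Neither measured step touches this place, and both were within the scatter, so no step beyond the scatter is expected in this assay, and the estimated change is a number 4 percentage points lower from compound 1 to compound 4 (within the scatter). Compound 4 is therefore expected to give about 55%, within a range from 40% to 68%.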

Compound 4, a percentage reported as inhibition, in the whole organism at one dose (the size of the read-out at that dose, not a potency): 64%
The estimate for compound 4 lay 9 percentage points below the measured number, within the range that was stated.
By their numbers in this assay, from the lowest: compounds 1, 2, 4 and 3 (each within the scatter of the next).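

In this assay, replacing 3,4-dimethoxyphenyl with phenyl on this aromatic carbon gives a number 5 percentage points higher from compound 1 to compound 4 (within the scatter). Going by these compounds alone, this is the first look at this position, and it shows that the inhibition at the one dose given stays within the scatter when the two hydrogen-bond acceptors of the 3,4-dimethoxyphenyl group are lost. No supporting measurement explains this result.

On these data alone, it remains open whether an amine or a carboxylic acid on this phenyl would move the number beyond the scatter. Also open, as far as these compounds go, is how phenyl at this place behaves alongside allyl on the ring nitrogen.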